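A few compounds are considered here, and "the series" means these few. Any claim that something is new, unique, unknown or untested is made for them only; others in the source may bear on it.

Working notes on the series. Compound 1 `CCCCCC(=O)Nc1nnc(S[C@@H]2O[C@H](CO)[C@H](O)[C@H](O)[C@H]2O)s1` and compound 2 `CCCCCCCCCCCCCC(=O)Nc1nnc(S[C@@H]2O[C@H](CO)[C@H](O)[C@H](O)[C@H]2O)s1` share the unprotected core; compound 3 `CCCCCCCCCCCCCCCCCC(=O)Nc1nnc(S[C@@H]2O[C@H](COC(C)=O)[C@H](OC(C)=O)[C@H](OC(C)=O)[C@H]2OC(C)=O)s1` and compound 4 `CCCCCCCCCC(=O)Nc1nnc(S[C@@H]2O[C@H](COC(C)=O)[C@H](OC(C)=O)[C@H](OC(C)=O)[C@H]2OC(C)=O)s1` carry the acetylated core, and the difference between the two cores is not broken down here. In a functional assay on HeLa cells (Homo sapiens) for cytotoxicity, read by MTT assay, with a stated time of 24 h (a lower number here means a stronger inhibitor, a higher number a weaker inhibitor), compound 2 gives 31000 nM and compound 1 gives 45600 nM; the change hydrogen in place of octyl on a saturated chain carbon, five bonds along the chain from a carbonyl carbon produced a 1.5-fold higher number from compound 2 to compound 1 (0.17 log units; within the scatter). Compound 3 gives 97500 nM in this assay, the highest number of the three measured. The change hydrogen in place of octyl on a saturated chain carbon, nine bonds along the chain from a carbonyl carbon is the same kind of change, but the place differs: five bonds along the chain from a carbonyl carbon in the first case, nine bonds in the second. Because the step of a 1.5-fold higher number from compound 2 to compound 1 (0.17 log units; within the scatter) stayed within the scatter, a step of similar size, a 1.1-fold higher number from compound 3 to compound 4 (0.05 log units; within the scatter), is expected from compound 3 to compound 4 in this assay. Compound 4 is therefore estimated at 110000 nM.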

Compound 4, half-maximal inhibitory concentration: 44900 nM
Beside the measured number, compound 4's estimate is 2.4-fold (0.39 log units) above it, outside the stated range (below it).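

In this assay, hydrogen in place of octyl on the acetylated core gives a 2.2-fold lower number from compound 3 to compound 4 (0.34 log units; beyond the scatter), and this step does not match the one seen on the unprotected core: the same change on two cores in this assay, a 1.5-fold higher number (0.17 log units; within the scatter) from compound 2 to compound 1 and a 2.2-fold lower number (0.34 log units; beyond the scatter) from compound 3 to compound 4, 3.2-fold (0.50 log units) apart, beyond the scatter of two such steps. In this series, therefore, the step read on one core does not carry over to the other for this change. This does not separate the effect of the core from that of the place, since the change lies five bonds along the chain from a carbonyl carbon in one pair and nine bonds in the other, and each core rests on a single pair.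

Still open, on these data alone, are how the two cores compare on one and the same chain and how an amine or a carboxylic acid in place of octyl would read.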